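The compounds below may be only part of what the source reports. "The series", "measured", "known", "first", "only" and "open" are said of these compounds alone.

Series notes, whole-animal inhibition

The series is read in a functional assay on the whole organism (strain Wistar albino) for inhibition, with Rattus norvegicus as the target, read by paw edema, with stated times of 1 h and 3 h, at a dose of 0.32 mmol/kg by the intraperitoneal route; a lower number here means less inhibition, a higher number more inhibition at the dose given (going by the name of the read-out). Compound 1 `COc1ccc(-c2nn(-c3ccc(Cl)cc3)cc2C(CC(=O)c2ccc(Cl)cc2)C(=O)c2ccc(F)cc2)cc1` gives 37.8%. Compound 2 `COc1ccc(C(=O)C(CC(=O)c2ccc(Cl)cc2)c2cn(-c3ccc(Cl)cc3)nc2-c2ccc(OC)cc2)cc1` differs from compound 1 by methoxy in place of fluoro on an aromatic carbon, and in this assay compound 2 gives 9.61%; the step of a number 28.2 percentage points lower from compound 1 to compound 2 (beyond the scatter) is therefore downward and beyond the usual scatter.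

Compound 3 `COc1ccc(-c2nn(-c3ccc(Cl)cc3)cc2-c2cc(-c3ccc(Cl)cc3)[nH]c2-c2ccc(F)cc2)cc1` stands on a different core; the difference between the core of compound 3 and the core of compound 1 is not broken down here. In this assay compound 3 gives 61.9%, the highest of the three numbers measured, with the steps to compound 1 and to compound 2 both beyond the scatter.

Compound 4 `COc1ccc(-c2nn(-c3ccc(Cl)cc3)cc2-c2cc(-c3ccc(Cl)cc3)[nH]c2-c2ccc(OC)cc2)cc1` has not yet been measured. Among the compounds with values here, it differs from compound 3 by methoxy in place of fluoro on an aromatic carbon, which is the same change, at the same kind of place, as the one made from compound 1 to compound 2. Within the data shown here, with the change occurring only twice in the set, the single measured instance is the only guide. The expected step is a number 23.9 percentage points lower from compound 3 to compound 4 (beyond the scatter), resting on the measured step of a number 28.2 percentage points lower from compound 1 to compound 2 (beyond the scatter) and allowing that the core of compound 3 may not answer the change in exactly the same way. Compound 4 is accordingly expected to give 38% in this assay, with an estimated range from 20% to 56%.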

Compound 4, a percentage reported as inhibition, in the whole organism at one dose (the size of the read-out at that dose, not a potency): 20.7%
Beside the measured number, compound 4's estimate is 17.3 percentage points above it; measured number inside the range.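

On the second core the change from 4-fluorophenyl to 4-methoxyphenyl again lowers the number in this assay, giving a number 41.2 percentage points lower from compound 3 to compound 4 (beyond the scatter). Set beside the first instance, the two steps run in the same direction and their sizes cannot be separated: the same change on two cores in this assay, a number 28.2 percentage points lower (beyond the scatter) from compound 1 to compound 2 and a number 41.2 percentage points lower (beyond the scatter) from compound 3 to compound 4, 13 percentage points apart, within the scatter of two such steps. On these two cores the change therefore carries over, downward and by a comparable amount, but two pairs give no rule for any further core, do not show that one core answers the change more strongly than the other, and, being read at a single dose, describe the size of the read-out at that dose and not a potency.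

The compounds shown hold only fluoro and methoxy at this place, which leaves open how a plain phenyl, a hydroxyl, an amine or a carboxylic acid there would read in this assay, and so whether the fall belongs to methoxy in particular or would follow from other replacements of fluoro. Also open is whether the same change would give a similar step with the 4-chlorophenyl groups elsewhere in these molecules replaced, since those groups stay the same in all the compounds shown.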